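This account rests on a few compounds, and the source may have more. Where it says the series, first, only, none or still open, it means among the compounds named here.

Of the compounds shown here, two have been measured so far in a functional assay on MCF7 cells (Homo sapiens) for cytotoxicity, read by MTT assay, with a stated time of 48 h; on this read-out lower numbers stand for stronger inhibition and higher numbers for weaker inhibition. Compound 1 (`COc1cc(/C=C/C(=O)/C=C/c2nc3c(C)c(C)ccc3n2C)ccc1O`) gives 14100 nM, and compound 2 (`COc1ccc(/C=C/C(=O)/C=C/c2nc3cc(C)ccc3n2C)cc1O`) gives 3600 nM. Compound 2 therefore holds the lower number of the two, and its gap to compound 1 lies beyond the usual scatter of repeated measurements. Compound 3 (`COc1ccc(/C=C/C(=O)/C=C/c2nc3c(C)c(C)ccc3n2C)cc1O`) has not yet been measured and departs from compound 2 in one place: methyl in place of hydrogen on an aromatic carbon, with methyl in place of hydrogen on an aromatic carbon. Going by the values given here, no two measured compounds differ in a single place, so the data hold no measured step for this change in this assay. Among the compounds with values here, the only other guide is compound 1 at 14100 nM, which stands on the weaker side of compound 2, although that gap cannot be tied to any one change. A small move towards weaker inhibition is therefore expected, with the estimated step being a 1.5-fold higher number from compound 2 to compound 3 (0.18 log units; within the scatter). For compound 3 the estimated value is 5500 nM, with an expected range from 2200 nM to 13000 nM.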

Compound 3, half-maximal inhibitory concentration: 3500 nM
Compound 3: the middle estimate sits 1.6-fold (0.20 log units) above what was measured, and the stated range covers the measured number.
By their numbers in this assay, from the lowest: compounds 3 and 2 (each within the scatter of the next); then compound 1.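

With the assay named as this assay, placing a methyl in place of hydrogen on the aromatic carbon ortho to a methyl group gives a 1.0-fold lower number from compound 2 to compound 3 (0.01 log units; within the scatter), so at this position, in this one comparison, the added methyl leaves the number within the scatter. Going by these compounds alone, the exchange of 4-hydroxy-3-methoxyphenyl for 3-hydroxy-4-methoxyphenyl gives a 4.0-fold lower number from compound 1 to compound 3 (0.61 log units; beyond the scatter), a step beyond the scatter, and this supplies a single-place comparison that the earlier compounds lacked, with the larger step falling on the phenyl exchange and not on the methyl. Nothing further in the data explains either step.

Going by these compounds, what remains open is whether this aromatic carbon would tolerate something other than methyl, such as an ethyl, a methoxy, an amine or a carboxylic acid, as quietly as it does the methyl, since one small group on one background says little about the position as a whole. Within the data shown here, it is also open whether the phenyl exchange would give a step of similar size on a core carrying the single methyl of compound 2, and whether either result extends beyond this one cell line.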